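A few compounds are considered here, and "the series" means these few. Any claim that something is new, unique, unknown or untested is made for them only; others in the source may bear on it.

In a functional assay on COLO 205 cells (Homo sapiens) for inhibition, read by MTT assay, with a stated time of 24 h (a higher number here means a weaker inhibitor, a lower number a stronger inhibitor), compound 1 `C/C=C(\C)C(=O)O[C@@H]1[C@]2(OC(=O)C3CC3)C=C3C4=CC(=O)O[C@@H](c5ccoc5)[C@]4(C)CC[C@@H]3[C@@]3(C)[C@H](C[C@]1(C)[C@H]3[C@@H](O)C(=O)OC)O2` reads > 100000 nM, a limit of the assay and not a number. Compound 2 `C/C=C(\C)C(=O)O[C@@H]1[C@]2(OC(=O)CC)C=C3C4=CC(=O)O[C@@H](c5ccoc5)[C@]4(C)CC[C@@H]3[C@@]3(C)[C@H](C[C@]1(C)[C@H]3[C@@H](O)C(=O)OC)O2` reads > 100000 nM, likewise a limit. The common reading is the limit of > 100000 nM in this assay, at which 2 of the 2 values shown sit. The pair shows only a step that the two limits leave unreadable from compound 1 to compound 2, and that gives no size to carry forward. Compound 3 `C/C=C(\C)C(=O)O[C@@H]1[C@]2(OC(=O)CC)C=C3C4=CC(=O)O[C@@H](c5ccoc5)[C@]4(C)CC[C@@H]3[C@@]3(C)[C@H](C[C@]1(C)[C@H]3[C@@H](OC(=O)CC)C(=O)OC)O2` differs from compound 2 by propanoyl in place of hydrogen on an oxygen on a saturated carbon. Going by the values given here, no measured step covers this change. The expected step is an at least 1.2-fold lower number from compound 2 to compound 3 (0.09 log units; that floor lies within the scatter), with no firm direction, and another limit reading is the likeliest outcome. Compound 3 is estimated at 80000 nM, with an expected range of 25000 nM to 150000 nM.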

Compound 3, half-maximal inhibitory concentration: > 100000 nM
Compound 3: a limit, no number (the forecaster's own chance of this, stated with the estimate: 70%); at least 1.2-fold (0.09 log units) between middle value and limit.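

Compound 3 reads > 100000 nM, a limit and not a number, so no step can be read from compound 2 to compound 3. The compounds shown leave open whether any of these changes alters the reading at all, since all sit at one value: the limit of > 100000 nM in this assay, at which 3 of the 3 values shown sit.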